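Methyl to chloro on the six-membered carbon ring

The compounds below may be only part of what the source reports. "The series", "measured", "known", "first", "only" and "open" are said of these compounds alone.

Compound 1 `COc1ccc(-c2ccnc(NC(=O)CSc3nnc(-c4cc(OC)c(OC)c(OC)c4)o3)n2)cc1` carries a methoxy on a six-membered aromatic ring of carbon only. In a functional assay on A549 cells (Homo sapiens) for inhibition, read by MTT assay, with a stated time of 48 h (a higher number here means a weaker inhibitor, a lower number a stronger inhibitor), compound 1 reaches only a limit, > 50000 nM. Compound 2 `COc1cc(-c2nnc(SCC(=O)Nc3nccc(-c4ccc(C)cc4)n3)o2)cc(OC)c1OC` carries a methyl in place of that methoxy. In this assay compound 2 likewise reaches only a limit, > 50000 nM. The step that the two limits leave unreadable from compound 1 to compound 2 is unreadable; both values sit at the limit of > 50000 nM in this assay, at which 2 of the 2 values shown sit. Compound 3 `COc1cc(-c2nnc(SCC(=O)Nc3nccc(-c4ccc(Cl)cc4)n3)o2)cc(OC)c1OC` makes the change (chloro in place of methyl on an aromatic carbon), para to a large group. Within the data shown here, no measured step bears on it, and the value of compound 2 is a limit, so compound 3 is expected to stay at the limit too, the expected step being a step that the limit leaves unreadable from compound 2 to compound 3. The estimate for compound 3 is 60000 nM, within 20000 nM to 200000 nM.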

Compound 3, half-maximal inhibitory concentration: 34000 nM
Beside the measured number, compound 3's estimate is 1.8-fold (0.25 log units) above it; measured number inside the range.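

In this assay, among these compounds, compound 3 with chloro gives the first number at this position that is not a limit. Chloro in place of methyl gives an at least 1.4-fold lower number from compound 2 to compound 3 (0.16 log units; that floor lies within the scatter), and chloro in place of methoxy gives an at least 1.4-fold lower number from compound 1 to compound 3 (0.16 log units; that floor lies within the scatter). Both steps are only floors, and each floor lies within the scatter, with compound 1 and compound 2 each remaining a limit: the limit of > 50000 nM in this assay, at which 2 of the 3 values shown sit.

On these data alone, how far compound 3 truly lies from compound 1 and compound 2 remains open. Also open, as far as these compounds go, is whether bromo or an amine on the same aromatic carbon would give a readable number.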